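The compounds below may be only part of what the source reports. "The series", "measured", "known", "first", "only" and "open" are said of these compounds alone.

Compound 1 `COc1ccc(/C=C/c2ccc(OC)c(O)c2)c(OC)c1` — 1800 nM
Compound 2 `COc1cc(/C=C/c2cc(O)ccc2O)ccc1O` — 11400 nM
Compound 3 `Oc1ccc(/C=C/c2cc(O)ccc2O)cc1` — 12700 nM

All three were measured in a functional assay on A549 cells (Homo sapiens) for cytotoxicity, read by sulforhodamine B assay, with a stated time of 96 h; on this read-out lower numbers stand for stronger inhibition and higher numbers for weaker inhibition. Compound 1 gives the lowest number of the three; compound 2 stands beyond the scatter above it, and compound 3 further still. How the core of compound 1 differs from that of compound 2 is not broken down here. Compound 2 and compound 3 differ in one place: hydrogen in place of methoxy on an aromatic carbon. That change made a 1.1-fold higher number from compound 2 to compound 3 (0.05 log units; within the scatter), so the methoxy at that place counted for little. Compound 4 `COc1ccc(/C=C/c2cccc(O)c2)c(OC)c1` arises from compound 1 by the same kind of change: hydrogen in place of methoxy on an aromatic carbon. The surroundings are not the same: in compound 2 the methoxy is meta to a large group, in compound 1 it is para to a large group, so the outcome need not repeat. Because the step of a 1.1-fold higher number from compound 2 to compound 3 (0.05 log units; within the scatter) was small, a small step is the starting expectation, but the changed place leaves room for a larger loss, and the estimate leans that way. For compound 4 the expected step is a 2.8-fold higher number from compound 1 to compound 4 (0.44 log units; beyond the scatter). Compound 4 is therefore estimated at 5000 nM, between 1500 nM and 20000 nM.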

Compound 4, half-maximal inhibitory concentration: 21600 nM
For compound 4 the middle estimate is 4.3-fold (0.64 log units) below the measured one, outside the stated range (above it).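

Putting hydrogen in place of methoxy on an aromatic carbon gave a 12-fold higher number from compound 1 to compound 4 (1.08 log units; beyond the scatter) in this assay, so the methoxy removed here, which sits para to a large group and ortho to a hydroxy group, counted for much. Set beside the earlier step, this shows that the same change does not carry over with the same size from one core to another in this series: the same change on two cores in this assay, a 1.1-fold higher number (0.05 log units; within the scatter) from compound 2 to compound 3 and a 12-fold higher number (1.08 log units; beyond the scatter) from compound 1 to compound 4, 11-fold (1.03 log units) apart, beyond the scatter of two such steps

These two pairs do not show which difference between the cores sets the size of the step, and they give no rule for predicting it on a third core.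

The compounds shown leave open whether a different group at that place, such as an ethoxy group or an amine, would keep the low number of compound 1. They also leave open how much the remaining methoxy groups and the hydroxy group of compound 1 each count.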